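Notes on halide variation at the ring amine nitrogen

The source may hold more compounds than are shown below. What is called first, only, known or untested is meant among the compounds shown, and "the series" means these compounds.

Measured in an assay on CHO cells for displacement of a labelled ligand from adenosine receptor A2b (Homo sapiens), read by scintillation counting, with a stated time of 75 min, in the presence of a further agent that is not named here; on this read-out higher numbers stand for weaker inhibition and lower numbers for stronger inhibition:
Compound 1 `CCCn1c(=O)[nH]c2nc(-c3ccc(S(=O)(=O)N4CCN(c5ccc(Br)cc5)CC4)cc3)[nH]c2c1=O` gives 0.0835 nM.
Compound 2 `CCCn1c(=O)[nH]c2nc(-c3ccc(S(=O)(=O)N4CCN(c5ccc(C)cc5)CC4)cc3)[nH]c2c1=O` gives 0.706 nM.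
Compound 3 `CCCn1c(=O)[nH]c2nc(-c3ccc(S(=O)(=O)N4CCN(Cc5ccc(Br)c(F)c5)CC4)cc3)[nH]c2c1=O` gives 0.473 nM.

Compound 3 holds the second highest of the three numbers. Its nearest neighbour is compound 2, with a 1.5-fold lower number from compound 2 to compound 3 (0.17 log units; within the scatter) lying within the scatter, so no order between them is claimed; its furthest is compound 1, with a 5.7-fold higher number from compound 1 to compound 3 (0.75 log units; beyond the scatter) lying beyond the scatter.

Compound 4 `CCCn1c(=O)[nH]c2nc(-c3ccc(S(=O)(=O)N4CCN(c5ccc(I)cc5)CC4)cc3)[nH]c2c1=O` differs from compound 3 by 4-iodophenyl in place of 4-bromo-3-fluorobenzyl on an amine nitrogen in a ring. For the measured compounds named here, two measured steps bear on this. Read backwards, a 5.7-fold higher number from compound 1 to compound 3 (0.75 log units; beyond the scatter) shows that a 4-bromophenyl directly on the ring nitrogen gave a lower number than a benzyl group there. an 8.5-fold higher number from compound 1 to compound 2 (0.93 log units; beyond the scatter) shows that methyl in place of bromo raised the number. Going by the values given here, no measured step compares iodo with bromo, so compound 4 is expected to land close to compound 1, with that comparison the open uncertainty. The expected step is a 4.7-fold lower number from compound 3 to compound 4 (0.67 log units; beyond the scatter), downward and beyond the scatter. Compound 4 is estimated at 0.1 nM, within a range of 0.03 nM to 0.4 nM.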

Compound 4, inhibition constant: 0.159 nM
Compound 4: the middle estimate sits 1.6-fold (0.20 log units) below what was measured, within the range that was stated.
By their numbers in this assay, from the lowest: compounds 1 and 4 (each within the scatter of the next); then compounds 3 and 2 (each within the scatter of the next).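

In this assay, iodo in place of bromo on the aromatic carbon (a 1.9-fold higher number from compound 1 to compound 4 (0.28 log units; within the scatter)) leaves the two halogens unresolved at this position. Iodo in place of methyl (a 4.4-fold lower number from compound 2 to compound 4 (0.65 log units; beyond the scatter)) gives a second halogen step beyond the scatter, and 4-iodophenyl in place of 4-bromo-3-fluorobenzyl on the ring amine nitrogen (a 3.0-fold lower number from compound 3 to compound 4 (0.47 log units; beyond the scatter)) shows that a second 4-halophenyl group also gives a lower number than this benzyl group. No evidence is available to explain these steps.

On these data alone, the effect of a chloro, amino or carboxylic acid group on the same phenyl ring remains open. 4-Bromo-3-fluorobenzyl differs from 4-bromophenyl by both a methylene link and a fluoro group, so a 4-bromobenzyl group would be needed to separate the two changes.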